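A few compounds are considered here, and "the series" means these few. Any claim that something is new, unique, unknown or untested is made for them only; others in the source may bear on it.

Measured compounds in a functional assay on HOS cells (Homo sapiens) for inhibition, read by CCK-8 assay, with a stated time of 72 h, tested at 1 uM; on this read-out higher numbers stand for more inhibition at the one concentration tested (going by the name of the read-out) and lower numbers for less inhibition:
compound 1 `O=C(NCCCCc1ccccc1)c1cccc(C2SCC(=O)N2c2cccc(F)c2)c1` gives 84%
compound 2 `COc1cc(F)ccc1N1C(=O)CSC1c1cccc(C(=O)NCCCCc2ccccc2)c1` gives 81%
compound 3 `COc1c(F)cccc1N1C(=O)CSC1c1cccc(C(=O)NCCCCc2ccccc2)c1` gives 9%

Compound 3 stands lowest of the three numbers in this assay. Its nearest neighbour is compound 2, the step being a number 72 percentage points lower from compound 2 to compound 3 (beyond the scatter), and its furthest is compound 1, the step being a number 75 percentage points lower from compound 1 to compound 3 (beyond the scatter). Compound 1 and compound 2 lie within the scatter of each other, with a number 3 percentage points lower from compound 1 to compound 2 (within the scatter).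

Compound 4 `O=C(NCCCCc1ccccc1)c1cccc(C2SCC(=O)N2c2ccccc2F)c1` is not yet measured. It differs from compound 3 in one place: 2-fluorophenyl in place of 3-fluoro-2-methoxyphenyl on an amide-type nitrogen in a ring

Going by the values given here, two measured steps bear on this change. The step of a number 75 percentage points lower from compound 1 to compound 3 (beyond the scatter) shows what the methoxy on the aromatic carbon did when put in place of hydrogen, and the step of a number 72 percentage points lower from compound 2 to compound 3 (beyond the scatter) shows the two fluoro-methoxyphenyl variants against each other. Compound 4 carries no methoxy at all and keeps a single fluorine on the phenyl, as compound 1 does. A large step upward in this assay is therefore expected, because compound 1 with its 3-fluorophenyl gives 84%. The expected step is a number 61 percentage points higher from compound 3 to compound 4 (beyond the scatter). Compound 4 is estimated at 70%, with a range from 40% to 90%.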

Compound 4, a percentage reported as inhibition, at one concentration (the size of the read-out at that concentration, not a potency): 83%
Estimate against measurement, compound 4: 13 percentage points below; low and high end bracket the measured number.
By their numbers in this assay, from the lowest: compound 3; then compounds 2, 4 and 1 (each within the scatter of the next).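

In this assay, 2-fluorophenyl on the amide-type nitrogen in the ring gives a number 74 percentage points higher from compound 3 to compound 4 (beyond the scatter) and so shows that a fluorophenyl with its fluorine placed differently from compound 1 can still carry a high number, while the 3-fluoro-2-methoxyphenyl of compound 3 remains the one low case. The comparisons a number 2 percentage points higher from compound 2 to compound 4 (within the scatter) and a number 1 percentage points lower from compound 1 to compound 4 (within the scatter) show that, at this one concentration, this position accepts 2-fluorophenyl, 3-fluorophenyl and 4-fluoro-2-methoxyphenyl without a separation beyond the scatter, so that among the four compounds only compound 3 goes against this pattern. Nothing available here accounts for the drop seen with the 3-fluoro-2-methoxyphenyl group.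

Open, going by these compounds, is whether the low number of compound 3 needs both its methoxy and its fluorine, which a methoxyphenyl without fluorine on this nitrogen would test. Also open, on these data alone, is how an unsubstituted phenyl, an aminophenyl or a phenyl bearing a carboxylic acid would read at this position, and whether compounds 1, 2 and 4 would show a stronger or weaker effect than one another at other concentrations, which a single concentration cannot tell.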